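A few compounds are considered here, and "the series" means these few. Any claim that something is new, unique, unknown or untested is made for them only; others in the source may bear on it.

Measured in a functional assay on NCI-H460 cells (Homo sapiens) for cytotoxicity, read by MTT assay, with a stated time of 68 h; on this read-out higher numbers stand for weaker inhibition and lower numbers for stronger inhibition:
Compound 1 `O=C(Nc1cccc(-c2ccccc2C(F)(F)F)c1)C(Cl)Cl` gives 7550 nM
Compound 2 `O=C(Nc1cccc(-c2ccsc2)c1)C(Cl)Cl` gives > 50000 nM

Compound 2 stands at > 50000 nM in this assay, which is a limit of the assay and not a number. Compound 3 `O=C(Nc1cccc(-c2ccccn2)c1)C(Cl)Cl` carries pyridin-2-yl in place of thiophen-3-yl on an aromatic carbon and has yet to be measured. Within the data shown here, no measured pair shows what this exchange does. A small step toward stronger inhibition is expected, or none beyond the scatter, and compound 3 may well return only a limit too. Compound 1 (7550 nM) shows that the shared core can give a number in this assay, but it carries a different group. The estimated change is an at least 1.6-fold lower number from compound 2 to compound 3 (0.22 log units; that floor lies within the scatter) in size. For compound 3 the expected value is 30000 nM, with an estimated range of 10000 nM to 60000 nM.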

Compound 3, half-maximal inhibitory concentration: > 50000 nM
Compound 3 was reported as a limit (the forecaster's own chance of this, stated with the estimate: 40%); middle value at least 1.6-fold (0.22 log units) from the limit.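

Compound 2 and compound 3 both return limits and not numbers, so no step can be read between them: the limit of > 50000 nM in this assay, at which 2 of the 3 values shown sit.

The compounds shown leave open how strongly either compound inhibits, and whether pyridin-2-yl in place of thiophen-3-yl changes inhibition at all.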